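Swapping an Oxane Arm for a Dimethylcyclohexyl Ring

The source may report more compounds than this note shows. Statements on the series, on what has been measured and on what is new or still open speak of the compounds shown alone.

Three compounds share one core and differ only in the group on the outer amine. Compound 1 `c1ccc2c(c1)CN[C@@H](CN(CCCCNCC1CCCCC1)[C@H]1CCCc3cccnc31)C2` carries a cyclohexylmethyl group, compound 2 `c1ccc2c(c1)CN[C@@H](CN(CCCCNC1CCSCC1)[C@H]1CCCc3cccnc31)C2` a thian-4-yl group, and compound 3 `CC(C)(CCN(C[C@H]1Cc2ccccc2CN1)[C@H]1CCCc2cccnc21)CNCC1CCOCC1` an (oxan-4-yl)methyl group on a branched chain. All were tested in a functional assay on cells for agonist activity at C-X-C chemokine receptor type 4 (Homo sapiens), read by fluorescence and calcium flux, with a stated time of 90 s; a lower number here means that less compound is needed, a higher number that more compound is needed for the effect. Compound 1 gives only a limit of the assay, > 30000 nM. Compound 2 also gives only a limit, > 30000 nM. Compound 3 likewise gives only a limit, > 30000 nM. With every value at the limit, the steps a step that the two limits leave unreadable from compound 1 to compound 2, a step that the two limits leave unreadable from compound 1 to compound 3 and a step that the two limits leave unreadable from compound 2 to compound 3 have no readable size or direction; the limit of > 30000 nM in this assay, at which 3 of the 3 values shown sit, is the whole of what the numbers show.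

Compound 4 `CC1(C)CCC(NCC(C)(C)CCN(C[C@H]2Cc3ccccc3CN2)[C@H]2CCCc3cccnc32)CC1` changes compound 3 by 4,4-dimethylcyclohexyl in place of (oxan-4-yl)methyl on an amine nitrogen. Compound 1 already shows that a carbon-only ring on that amine gives > 30000 nM, a limit. Compound 4 is therefore expected to give 30000 nM, within 10000 nM to 100000 nM, most likely again as a limit rather than a number. The expected step of a number no higher from compound 3 to compound 4 (the limit leaves the size open) is thus no readable change.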

Compound 4, half-maximal effective concentration: > 30000 nM
Compound 4: a limit, no number; the forecaster's own chance of this, stated with the estimate: 80%; the middle value sits exactly at the limit.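

Compound 3 and compound 4 both give only a limit, not a number, so the step between them has no readable size or direction: the limit of > 30000 nM in this assay, at which 4 of the 4 values shown sit. The compounds shown leave open how far each lies past that limit, and whether any group on this amine nitrogen would give a measurable value.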